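The compounds below may be only part of what the source reports. "The series", "measured", "known", "first", "only" and "open" are said of these compounds alone.

Among the compounds with values here, in a functional assay on MDA-MB-435 cells (Homo sapiens) for antiproliferative activity, read by sulforhodamine B assay, with a stated time of 72 h (a lower number here means a stronger inhibitor, a higher number a weaker inhibitor), compound 2 (`Cc1cc(C)nc(NS(=O)(=O)c2ccc(Nc3nncc4ccccc34)cc2)n1`) gives 3.4 nM and stands at the low end of the three numbers known so far. Compound 3 (`Fc1ccc(Nc2nncc3ccccc23)cc1`) gives 4 nM and lies within the scatter of compound 2, so the two cannot be ranked. Compound 1 (`O=C1CS/C(=N/Nc2nncc3ccccc23)N1c1ccccc1`) gives 44 nM and stands beyond the scatter on the higher, weaker side of compound 2.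

Compound 4 (`Cc1cc(NS(=O)(=O)c2ccc(Nc3nncc4ccccc34)cc2)no1`) has not yet been measured. It differs from compound 2 in one place, with 5-methyl-1,2-oxazol-3-yl in place of 4,6-dimethylpyrimidin-2-yl on a sulfonamide nitrogen. Within the data shown here, no measured pair shows a change at this nitrogen, so the expectation rests on little. In this assay compound 3, which has no sulfonamide at all, still gives 4 nM and this suggests that the group on that nitrogen need not set the number. No step beyond the scatter is therefore expected, and any small drift is expected toward a higher number. The estimated change is a 1.5-fold higher number from compound 2 to compound 4 (0.17 log units; within the scatter) and no more than that is expected. For compound 4 the estimated value is 5 nM with an expected range from 1.5 nM to 25 nM in this measurement.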

Compound 4, half-maximal inhibitory concentration: 27 nM
Beside the measured number, compound 4's estimate is 5.4-fold (0.73 log units) below it; the measured number lies above the stated range.
By their numbers in this assay, from the lowest: compounds 2 and 3 (each within the scatter of the next); then compounds 4 and 1 (each within the scatter of the next).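

In this assay, within the data shown here, the replacement of 4,6-dimethylpyrimidin-2-yl by 5-methyl-1,2-oxazol-3-yl on a sulfonamide nitrogen gives a 7.9-fold higher number from compound 2 to compound 4 (0.90 log units; beyond the scatter) and so shows that, for this pair, the group on this nitrogen does move the number, which no earlier compound could show, as none of them varied there. The entering group has fewer heavy atoms and a five-membered aromatic ring in place of a six-membered one, while its counts of hydrogen-bond donors and acceptors match those of the group it replaces, so these matching counts do not separate compound 2 from compound 4. Nothing measured on these compounds explains the step, and ring size, hetero atoms and methyl groups all change together in this single replacement.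

The compounds shown leave open which of these changes carries the step, and a pyrimidin-2-yl without methyl groups or a 1,3-thiazol-2-yl on the same nitrogen would separate them. They also leave open where a plain methyl group on that nitrogen, or a primary sulfonamide with only hydrogen there, would stand relative to compound 2 and compound 4.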